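A few compounds are considered here, and "the series" means these few. Any claim that something is new, unique, unknown or untested is made for them only; others in the source may bear on it.

Compounds measured so far:
- compound 1 `Cn1cc(C2=C(c3nn(CCCn4cncn4)c4ncccc34)C(=O)NC2=O)c2ccccc21`: > 100000 nM
- compound 2 `Cn1cc(C2=C(c3nn(CCCN4CCCCC4)c4ncccc34)C(=O)N(c3ccccc3)C2=O)c2ccccc21`: 12300 nM
- compound 3 `Cn1cc(C2=C(c3nn(CCCN4CCCCC4)c4ncccc34)C(=O)N(c3ccc(Cl)cc3)C2=O)c2ccccc21`: > 100000 nM

All three compounds were tested in a functional assay on ECa-109 cells (Homo sapiens) for antiproliferative activity, read by MTT assay, with a stated time of 48 h; on this read-out lower numbers stand for stronger inhibition and higher numbers for weaker inhibition. For compound 1, the entry is a limit of the assay and not a number. For compound 3, > 100000 nM is likewise a limit and not a number. Compound 3 therefore stands at the limit of > 100000 nM in this assay, at which 2 of the 3 values shown sit.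

Compound 4 `Cn1cc(C2=C(c3nn(CCCN4CCCCC4)c4ncccc34)C(=O)N(c3cccc4ccccc34)C2=O)c2ccccc21` has naphthalen-1-yl in place of 4-chlorophenyl on an amide-type nitrogen in a ring. Among the measured compounds shown here, one measured step bears on this place: an at least 8.1-fold higher number from compound 2 to compound 3 (0.91 log units; beyond the scatter), with chloro in place of hydrogen on an aromatic carbon. For the measured compounds named here, that step is beyond the scatter, but no measured compound carries the naphthalen-1-yl group. Going by the values given here, compound 2, with its unsubstituted phenyl, gives the only number at 12300 nM. A value for compound 4 is therefore expected between this number and the limit, and another limit remains possible. The expected change is an at least 2.2-fold lower number from compound 3 to compound 4 (0.34 log units; beyond the scatter). Compound 4 is estimated at 45000 nM, with an expected range from 12000 nM to 100000 nM.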

Compound 4, half-maximal inhibitory concentration: 1830 nM
Estimate against measurement, compound 4: 25-fold (1.39 log units) above; measured number outside the range, below it.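

Read in this assay, the amide-type nitrogen in a ring emerges as a place where the number can fall as well as rise: naphthalen-1-yl in place of phenyl gives a 6.7-fold lower number from compound 2 to compound 4 (0.83 log units; beyond the scatter), whereas the earlier step here went only upward. Naphthalen-1-yl in place of 4-chlorophenyl gives an at least 54-fold lower number from compound 3 to compound 4 (1.73 log units; beyond the scatter), so aromatic groups of carbon on this nitrogen can differ widely in their effect on the read-out. Compound 3 remains a limit of the assay and not a number: the limit of > 100000 nM in this assay, at which 2 of the 4 values shown sit.

The compounds shown leave open whether the lower number follows from the second aromatic ring itself or from how it is attached, which naphthalen-2-yl on the same nitrogen would test. They also leave open whether 4-methylphenyl or 4-methoxyphenyl would behave like phenyl or like 4-chlorophenyl.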